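The compounds below may be only part of what the source reports. "The series", "measured", "known", "first", "only" and "open" are said of these compounds alone.

Compound 1 `COc1ccc2c(c1)OC(c1cccc([N+](=O)[O-])c1)C(c1ccccc1)C2=O` and compound 2 `COc1ccc2c(c1)OC(c1ccc([N+](=O)[O-])cc1)C(c1ccccc1)C2=O` share one core and differ only in the aryl group that sits on a saturated ring carbon. In a functional assay (on this read-out lower numbers stand for an effect already at smaller amounts and higher numbers for an effect only at larger amounts of compound), compound 1 gives 130000 nM. In this assay compound 2 reaches only a limit, > 2500000 nM, so its true value is not known. Going from the 3-nitrophenyl to the 4-nitrophenyl group, there is an at least 19-fold higher number from compound 1 to compound 2 (1.28 log units; beyond the scatter), and this step rests on (the limit of > 2500000 nM in this assay, at which 1 of the 2 values shown sits). Compound 2 thus stands at the limit of what this assay reports, the weaker end of the two values shown.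

Compound 3 `COc1ccc2c(c1)OC(c1ccc(Cl)cc1)C(c1ccccc1)C2=O` follows from compound 2 by a single change: chloro in place of nitro on an aromatic carbon. For the measured compounds named here, no measured step bears directly on this exchange; the only measured step moves the nitro group from one position to another and says nothing about replacing it with chloro. The expectation for compound 3 must therefore rest on compound 2 alone, whose value is only a limit. With that, compound 3 is expected to show an at least 2.5-fold lower number from compound 2 to compound 3 (0.39 log units; beyond the scatter), an estimate that leans on the limit of compound 2 and carries wide uncertainty. In this assay compound 3 is accordingly estimated at 1000000 nM, with a range from 100000 nM to 5000000 nM.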

Compound 3, half-maximal effective concentration: 165000 nM
The estimate for compound 3 lay 6.1-fold (0.78 log units) above the measured number; the range from low to high includes it.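

The change shows that this aromatic carbon, para to a large group, does not rule out a measurable effect: with the 4-nitrophenyl group the read-out stays at its limit, while the 4-chlorophenyl group gives a number within reach of the assay. In this assay, chloro in place of nitro gives an at least 15-fold lower number from compound 2 to compound 3 (1.18 log units; beyond the scatter), and this size is only a bound, as compound 2 is known only as a limit: the limit of > 2500000 nM in this assay, at which 1 of the 3 values shown sits.

Compared with the 3-nitrophenyl group, the 4-chlorophenyl group gives a 1.3-fold higher number from compound 1 to compound 3 (0.10 log units; within the scatter), so the large loss seen earlier for the 4-nitrophenyl group is not shared by every group at this place and does not appear with chloro.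

The compounds shown leave open whether chloro would behave the same way on the aromatic carbon that carries nitro in compound 1, and how an amine or a carboxylic acid in place of chloro would read out. They also leave open the true value of compound 2, and so the full size of the step from nitro to chloro.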